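This account rests on a few compounds, and the source may have more. Where it says the series, first, only, none or still open, it means among the compounds named here.

- Compound 1 `COc1cc(C(=O)c2cccc3[nH]ccc23)cc(OC)c1OC`: 50.7 nM
- Compound 2 `CCn1ccc2cc(C(=O)c3cc(OC)c(OC)c(OC)c3)ccc21`: 36 nM

In a functional assay on KB cells (Homo sapiens) for inhibition, with a stated time of 72 h (on this read-out lower numbers stand for stronger inhibition and higher numbers for weaker inhibition), compound 1 gives 50.7 nM and compound 2 gives 36 nM. These values lie within the usual scatter of each other, so compound 2 stands level with compound 1. Compound 3 `COc1cc(C(=O)c2ccc3c(ccn3CO)c2)cc(OC)c1OC` differs from compound 2 as follows: hydroxy in place of methyl on a saturated chain carbon bound to an aromatic nitrogen. This puts hydroxy in place of methyl on a saturated chain carbon bound to an aromatic nitrogen, turning ethyl into hydroxymethyl. Among the compounds with values here, no measured pair shows this change in this assay, so the expectation is only a modest move toward weaker inhibition, and it is uncertain. The expected step is a 1.9-fold higher number from compound 2 to compound 3 (0.29 log units; within the scatter). The estimate for compound 3 is 70 nM, within a range of 22 nM to 230 nM.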

Compound 3, half-maximal inhibitory concentration: 39 nM
Compound 3: the middle estimate sits 1.8-fold (0.25 log units) above what was measured; measured number inside the range.
By their numbers in this assay, from the lowest: compounds 2, 3 and 1 (each within the scatter of the next).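

Putting hydroxy in place of methyl, which turns ethyl into hydroxymethyl, gives a 1.1-fold higher number from compound 2 to compound 3 (0.03 log units; within the scatter) in this assay and leaves the two compounds level. This place on the saturated chain carbon bound to an aromatic nitrogen therefore accepts a hydroxy, with its hydrogen-bond donor and acceptor, at least in this pair. No available evidence bears on why the two stand level. From the compounds shown here alone, it remains open whether an amine, a carboxylic acid or a longer chain ending in hydroxy would also hold the inhibition here. One pair also cannot show whether this swap behaves alike on another core.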